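A few compounds are considered here, and "the series" means these few. Any claim that something is new, unique, unknown or untested is made for them only; others in the source may bear on it.

Among the measured compounds shown here, in a toxicity assay on Huh-7.5 cells (Homo sapiens) for inhibition, read by MTT assay, with a stated time of 96 h (a higher number here means that more compound is tolerated, a lower number that less compound is tolerated), compound 2 (`CN1CCN(Cc2ccc(NC(=O)c3ccc(OCCCCl)c([N+](=O)[O-])c3)cc2C(F)(F)F)CC1`) gives 6800 nM as the higher of the two numbers so far, and compound 1 (`CN1CCN(Cc2ccc(NC(=O)c3ccc(OCCCCCCl)c([N+](=O)[O-])c3)cc2C(F)(F)F)CC1`) gives 2140 nM as the lower. Compound 3 (`CN1CCN(Cc2ccc(NC(=O)c3ccc(OCCCCCl)c([N+](=O)[O-])c3)cc2C(F)(F)F)CC1`) keeps the core of compound 2 and changes one group: chloromethyl in place of chloro on a saturated chain carbon, three bonds along the chain from an oxygen on an aromatic ring. For the measured compounds named here, only one measured step bears on this change. It puts chloro in place of 2-chloroethyl at that same carbon and amounts to a modest move (a 3.2-fold higher number from compound 1 to compound 2 (0.50 log units; beyond the scatter)). Chloromethyl is longer than chloro and shorter than 2-chloroethyl, so compound 3 is expected to land inside that gap, although two compounds are thin evidence. The expected step is a small one toward a lower number (a 1.8-fold lower number from compound 2 to compound 3 (0.25 log units; within the scatter)). The estimated value for compound 3 is 3800 nM (range 2000 nM to 7500 nM).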

Compound 3, half-maximal cytotoxic concentration: 3740 nM
Compound 3: middle estimate off by 1.0-fold (0.01 log units), on the high side; the range from low to high includes it.
By their numbers in this assay, from the lowest: compounds 1, 3 and 2 (each within the scatter of the next, the first and the last beyond it).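

In this assay, a single lengthening of the chain at this position cannot be told apart from the scatter: chloromethyl in place of chloro gives a 1.8-fold lower number from compound 2 to compound 3 (0.26 log units; within the scatter) and, four bonds along the chain from the oxygen, chloro in place of chloromethyl gives a 1.7-fold higher number from compound 1 to compound 3 (0.24 log units; within the scatter) as the second small step. Only the full span from compound 1 to compound 2 is beyond the scatter, so among these three compounds no single chain length marks a clear break. Nothing shown here gives a reason for these numbers.

From the compounds shown here alone, whether a longer chain would carry the numbers further in the same direction remains open. So does the role of the chlorine, which an amine or a carboxylic acid in its place could test.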